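Replacing 3-bromo-4-fluorophenyl with pyridin-2-yl on the amide

A few compounds are considered here, and "the series" means these few. Any claim that something is new, unique, unknown or untested is made for them only; others in the source may bear on it.

In a functional assay on MGC-803 cells (Homo sapiens) for inhibition, read by MTT assay, with a stated time of 72 h (on this read-out higher numbers stand for weaker inhibition and lower numbers for stronger inhibition), compound 1 (`O=C(Nc1cccc(Cl)c1)C1CCN(C/C=C/c2ccccc2)CC1`) gives 11300 nM and compound 2 (`O=C(Nc1ccc(F)c(Br)c1)C1CCN(C/C=C/c2ccccc2)CC1`) gives 9270 nM so compound 2 stands level with compound 1 within the scatter. Compound 3 (`O=C(Nc1ccccn1)C1CCN(C/C=C/c2ccccc2)CC1`) carries pyridin-2-yl in place of 3-bromo-4-fluorophenyl on an amide-type nitrogen. Among the compounds with values here, the only measured step that bears on this is a 1.2-fold lower number from compound 1 to compound 2 (0.09 log units; within the scatter) and it stays within the scatter, but it exchanged one carbon-only aromatic ring for another, so it is a weak guide. In this assay the expected step is a 1.5-fold higher number from compound 2 to compound 3 (0.18 log units; within the scatter) so no change beyond the scatter is expected. For compound 3 the estimated value is 14000 nM with an expected range from 6000 nM to 35000 nM in this estimate.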

Compound 3, half-maximal inhibitory concentration: 45200 nM
Compound 3: the middle estimate sits 3.2-fold (0.51 log units) below what was measured; measured number above the stated range.
By their numbers in this assay, from the lowest: compounds 2 and 1 (each within the scatter of the next); then compound 3.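

In this assay, within the data shown here, swapping the halogen-bearing carbon ring for pyridin-2-yl on the amide nitrogen gives the first change beyond the scatter at this place: a 4.9-fold higher number from compound 2 to compound 3 (0.69 log units; beyond the scatter), and a 4.0-fold higher number from compound 1 to compound 3 (0.60 log units; beyond the scatter). Among these three compounds, then, this ring is not interchangeable, and inhibition weakens with pyridin-2-yl. Nothing available explains this loss. The swap adds a ring nitrogen and removes the halogens at once, so the compounds shown cannot separate the two changes. An unsubstituted phenyl ring on the same nitrogen would help to tell them apart.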